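The source may hold more compounds than are shown below. What is called first, only, known or untested is meant among the compounds shown, and "the series" means these compounds.

Measured compounds in an ADME assay on Huh-7 cells (Homo sapiens) for cytotoxicity, with a stated time of 3 days; a higher number here means that more compound is tolerated, a lower number that less compound is tolerated:

Compound 1 `Cc1ccc(-c2cc(NO)c(C(=O)NC3CCCCC3)c(=O)o2)cc1` gives 10100 nM.
Compound 2 `COc1ccc(NC(=O)c2c(NO)cc(-c3cccs3)oc2=O)cc1` gives a limit of the assay, > 20000 nM.
Compound 3 `O=C(Nc1ccc(F)cc1)c1c(NCCO)cc(-c2cccc(Br)c2)oc1=O` gives a limit of the assay, > 20000 nM.

Compound 3 thus stands at the limit of > 20000 nM in this assay, at which 2 of the 3 values shown sit, so no number is known for it in this assay, only that it lies beyond the range the assay reports. Going by the values given here, compound 1 is the one measured compound with a value inside the range.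

Compound 4 `COc1ccccc1NC(=O)c1c(NCCO)cc(-c2cccc(Br)c2)oc1=O` has not yet been measured in this assay. It differs from compound 3 in one place: 2-methoxyphenyl in place of 4-fluorophenyl on an amide-type nitrogen. Among the compounds with values here, no step between two measured compounds that differ in one place is available, so the size of this change in this assay has to be guessed from the shared pattern of compound 2 and compound 3 sitting at the limit of the assay.

The step expected a number no higher from compound 3 to compound 4 (the limit leaves the size open) is none beyond the scatter. Compound 4 is therefore expected to give about 20000 nM in this assay, with a range from 10000 nM to 40000 nM, and most likely to be reported as a limit again.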

Compound 4, half-maximal cytotoxic concentration: > 20000 nM
Compound 4: a limit, no number; the forecaster's own chance of this, stated with the estimate: 70%; the middle value sits exactly at the limit.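

Compound 4, like compound 3, gives only a limit, so no step can be read from one to the other: the limit of > 20000 nM in this assay, at which 3 of the 4 values shown sit.

The compounds shown leave open how far past that limit compound 2, compound 3 and compound 4 lie, and whether 2-methoxyphenyl in place of 4-fluorophenyl changes the tolerated concentration at all.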